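This account rests on a few compounds, and the source may have more. Where it says the series, first, only, none or still open, it means among the compounds named here.

Compounds measured in a functional assay on QGY7701 cells (Homo sapiens) for cytotoxicity, read by MTT assay, with a stated time of 24 h; on this read-out higher numbers stand for weaker inhibition and lower numbers for stronger inhibition:

Compound 1 `C=CC1=C(C(=O)NCc2ccccc2)C(c2ccc(OC)c(OC)c2)OC1`. In this assay compound 1 gives > 100000 nM, which is a limit of the assay and not a number.
Compound 2 `C=CC1=C(C(=O)NCCC)C(c2ccc(OC)c(OC)c2)OC1`. In this assay compound 2 gives > 100000 nM, again a limit of the assay.
Compound 3 `C=CC1=C(C(=O)NCc2ccc(Cl)cc2)C(c2ccc(OC)c(OC)c2)OC1`. In this assay compound 3 gives > 100000 nM, likewise a limit of the assay.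

Compound 3 thus stands at the same limit as the other two measured compounds; no ordering among the three can be read. The steps among them are all unreadable for the same reason: a step that the two limits leave unreadable from compound 1 to compound 2, a step that the two limits leave unreadable from compound 1 to compound 3 and a step that the two limits leave unreadable from compound 2 to compound 3 each run between two limits, and the common point is the limit of > 100000 nM in this assay, at which 3 of the 3 values shown sit.

Compound 4 `C=CC1=C(C(=O)Nc2ccccc2)C(c2ccc(OC)c(OC)c2)OC1` is not yet measured. It differs from compound 3 in that (phenyl in place of 4-chlorobenzyl on an amide-type nitrogen). All three measured steps bear on the same amide-type nitrogen substituent and none of them shows any readable size, so no step beyond the scatter can be expected here in this assay in either direction; the most that the numbers support is that compound 4 will most likely also sit at the limit. The expected step is therefore a step that the limit leaves unreadable from compound 3 to compound 4. Compound 4 is estimated at 150000 nM in this assay, with a range from 40000 nM to 600000 nM, the estimate most probably ending as a limit rather than a number.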

Compound 4, half-maximal inhibitory concentration: > 100000 nM
Compound 4: only a limit was reported (the forecaster's own chance of this, stated with the estimate: 85%); the middle value lies beyond the limit too.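

For the compounds shown here, no step linking compound 4 with compound 1, compound 2 or compound 3 can be read, because all four stand at a limit of the assay and not at a number: the limit of > 100000 nM in this assay, at which 4 of the 4 values shown sit.

On these data alone, it remains open whether any substituent on the amide-type nitrogen of the shared core gives a numerical value in this assay and how such values would rank.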